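Moving the hydroxy group from 2-hydroxyphenyl to 4-hydroxyphenyl

The source may hold more compounds than are shown below. What is called first, only, known or untested is meant among the compounds shown, and "the series" means these compounds.

Compound 1 `O=C(Cc1csc2nc(-c3ccc(Br)cc3)cn12)N/N=C/c1ccccc1` gives 37200 nM in a functional assay on SF-295 cells (Homo sapiens) for inhibition, read by sulforhodamine B assay, with a stated time of 48 h (a higher number here means a weaker inhibitor of growth, a lower number a stronger inhibitor of growth), and serves as the reference. Among the compounds with values here, compound 2 `O=C(Cc1csc2nc(-c3ccc(Br)cc3)cn12)N/N=C/c1ccccc1O` gives 9330 nM in this assay and holds the lower of the two numbers so far. Within the data shown here, only one measured step bears on what follows: a 4.0-fold lower number from compound 1 to compound 2 (0.60 log units; beyond the scatter) when hydroxy replaces hydrogen on an aromatic carbon. Compound 3 `O=C(Cc1csc2nc(-c3ccc(Br)cc3)cn12)N/N=C/c1ccc(O)cc1` differs from compound 2 as follows 4-hydroxyphenyl in place of 2-hydroxyphenyl on a carbon with a double bond to nitrogen and so carries 4-hydroxyphenyl in place of 2-hydroxyphenyl on a carbon with a double bond to nitrogen. Among the measured compounds shown here, no measured pair tests this change directly, so the expectation rests on compound 2 at 9330 nM and compound 1 at 37200 nM as the nearest guides. The estimated move is a 1.7-fold higher number from compound 2 to compound 3 (0.23 log units; within the scatter) and is expected to run toward a higher number, without clearly leaving the scatter. In this assay compound 3 is estimated at 16000 nM with an expected range of 6500 nM to 40000 nM around that figure.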

Compound 3, concentration for total growth inhibition: 41700 nM
For compound 3 the middle estimate is 2.6-fold (0.42 log units) below the measured one; measured number above the stated range.
By their numbers in this assay, from the lowest: compound 2; then compounds 1 and 3 (each within the scatter of the next).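

In this assay, the gain seen earlier does not come from adding a hydroxy group to this aromatic ring as such, but depends on where it sits: replacing 2-hydroxyphenyl with 4-hydroxyphenyl on the carbon with a double bond to nitrogen gives a 4.5-fold higher number from compound 2 to compound 3 (0.65 log units; beyond the scatter), although the two groups have the same atoms and the same donor and acceptor counts. As 4-hydroxyphenyl, the hydroxy group leaves no change that stands out from the scatter, with a 1.1-fold higher number from compound 1 to compound 3 (0.05 log units; within the scatter). Nothing available explains why the two groups differ.

On these data alone, whether a methoxy group or an amine in the place held by hydroxy in compound 2 would keep its number remains open. As far as these compounds go, it is also open whether the difference between 2-hydroxyphenyl and 4-hydroxyphenyl would hold on any other core.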